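One Group Exchanged on a Carbonyl Carbon

The source may hold more compounds than are shown below. What is called first, only, known or untested is meant among the compounds shown, and "the series" means these compounds.

Measured so far in a toxicity assay on Vero cells (Chlorocebus sabaeus) for cytotoxicity, read by CCK-8 assay, with a stated time of 72 h; a higher number here means a weaker inhibitor, a lower number a stronger inhibitor:
- Compound 1 `Cc1ccc2oc(C)c(C(=O)NCc3ccc(N4CCC(c5ccc(OC(F)(F)F)cc5)CC4)cc3)c2c1`: "not determined" (no result reported)
- Compound 2 `Cc1nn2ccc(=O)[nH]c2c1C(=O)NCc1ccc(N2CCC(c3ccc(OC(F)(F)F)cc3)CC2)cc1`: "not determined" (no result reported)
- Compound 3 `Cc1nc2scc(C)n2c1C(=O)NCc1ccc(N2CCC(c3ccc(OC(F)(F)F)cc3)CC2)cc1`: > 100000 nM (a limit of the assay, not a number)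

Compound 1 has no single number to its name, so it offers no fixed starting point in this assay. The only reading among these compounds is the limit of > 100000 nM in this assay, at which 1 of the 3 values shown sits. Compound 3 owns that reading, and it is a limit rather than a number.

Still to be measured is compound 4 `Cc1nc2sccn2c1C(=O)NCc1ccc(N2CCC(c3ccc(OC(F)(F)F)cc3)CC2)cc1`. The structural change is a group of 9 heavy atoms (6 carbon, 2 nitrogen, 1 sulfur; 2 five-membered aromatic rings with 2 hetero atoms each) in place of a group of 11 heavy atoms (10 carbon, 1 oxygen; one five-membered aromatic ring with 1 hetero atom, one six-membered aromatic ring of carbon only), on a carbonyl carbon. On a carbonyl carbon, the 2,5-dimethyl-1-benzofuran-3-yl group leaves, and a group with no common name enters.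

With no number for compound 1, no size or direction of step can be read from it. The expectation rests on compound 3 alone, with its > 100000 nM, and points to little or no measurable effect in this assay. The reading may well come back as a limit again. For compound 4 the estimated value is 100000 nM, with an expected range from 40000 nM to 200000 nM.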

Compound 4, half-maximal inhibitory concentration: > 100000 nM
Compound 4 ended at the assay's limit; the forecaster's own chance of this, stated with the estimate: 85%; the middle value lies on the limit itself.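

Compound 3 and compound 4 differ only by hydrogen in place of methyl on an aromatic carbon, yet no step can be read between them, since each reading is a limit and not a number: the limit of > 100000 nM in this assay, at which 2 of the 4 values shown sit.

The compounds shown leave open at what concentration either would reach half-maximal inhibition in this assay, and whether that methyl changes it.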